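This account rests on a few compounds, and the source may have more. Where it says the series, first, only, none or still open, it means among the compounds named here.

Measured so far:
- compound 1, `CC1=C(C(=O)OC(C(F)(F)F)C(F)(F)F)C(c2ccoc2)NC(=O)N1`: 7%
- compound 2, `CC1=C(C(=O)OCC(F)(F)F)C(c2ccsc2)NC(=O)N1`: 2%

In an assay on cells for displacement of a labelled ligand from adenosine receptor A1 (Homo sapiens), read by radioligand binding, with a stated time of 60 min, tested at 1 uM (on this read-out higher numbers stand for more inhibition at the one concentration tested (going by the name of the read-out) and lower numbers for less inhibition), compound 1 gives 7%, and compound 2 gives 2%. Compound 2 carries the lower of the two numbers as written, but compound 1 sits within the usual scatter of it, so the two are not separated and neither can be called weaker or stronger. Both numbers lie near the bottom of the read-out.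

Compound 3, `CC1=C(C(=O)OCC(F)(F)F)C(c2ccoc2)NC(=O)N1`, has not been measured in this assay. It differs from compound 2 in one place: furan-3-yl in place of thiophen-3-yl on a saturated ring carbon. For the measured compounds named here, no step between measured compounds is available to gauge such a change; what the two measured values show is only that a five-membered aromatic ring with one hetero atom on the saturated ring carbon, paired with either ester, gives a low read-out.

On that basis no shift beyond the scatter is expected, and the step of a number 3 percentage points higher from compound 2 to compound 3 (within the scatter) is estimated to be small. Compound 3 is expected to give about 5% in this assay, with a range from 0% to 15%.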

Compound 3, a percentage reported as inhibition, at one concentration (the size of the read-out at that concentration, not a potency): 13%
For compound 3 the middle estimate is 8 percentage points below the measured one; low and high end bracket the measured number.
By their numbers in this assay, from the lowest: compounds 2, 1 and 3 (each within the scatter of the next, the first and the last beyond it).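

In this assay the saturated ring carbon now shows a first readable change: furan-3-yl in place of thiophen-3-yl gives a number 11 percentage points higher from compound 2 to compound 3 (beyond the scatter) and, with the ester held constant, the two rings are not interchangeable at this position even though they match in the counts given for heavy atoms, donors and acceptors. With furan-3-yl held fixed, hydrogen in place of trifluoromethyl on the saturated chain carbon bound to the ester oxygen gives a number 6 percentage points higher from compound 1 to compound 3 (within the scatter), so this change in the ester does not separate the two compounds on the present numbers. No measurement is available that accounts for the step at the ring position.

It remains open whether the step from thiophen-3-yl to furan-3-yl would carry over to the ester of compound 1, since only one such pair is shown. Also open, on these data alone, is what a phenyl ring, a pyridine ring or an amine on the same saturated ring carbon would give, and whether any such group would lift the read-out well clear of these low numbers.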